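The compounds below may be only part of what the source reports. "The series", "measured", "known", "first", "only" and "open" are said of these compounds alone.

Working notes on the series.

Compound 1 `O=c1c(-c2ccc(O)cc2)coc2cc(OCCCCBr)ccc12` gives 4000 nM in an assay on isolated protein (Cricetulus griseus) for inhibition of Monoamine oxidase (Homo sapiens); a lower number here means a stronger inhibitor, a higher number a weaker inhibitor. Within the data shown here, compound 2 `O=C(O)CCCCCCCCCOc1ccc2c(=O)c(-c3ccc(O)cc3)coc2c1` gives 10000 nM in this assay; the step of a 2.5-fold higher number from compound 1 to compound 2 (0.40 log units; beyond the scatter) is the only measured step so far. On these two numbers compound 2 stands highest, with compound 1 the nearer and only neighbour, a step beyond the scatter.

Compound 3 `O=C(O)CCCCCCOc1ccc2c(=O)c(-c3ccc(O)cc3)coc2c1` is not yet measured. It differs from compound 2 in one place: carboxy in place of 3-carboxypropyl on a saturated chain carbon, six bonds along the chain from an oxygen on an aromatic ring. The chain that ends in the acid is thus cut shorter, with the acid retained.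

Among the measured compounds shown here, only one measured step bears on this, and only loosely: a 2.5-fold higher number from compound 1 to compound 2 (0.40 log units; beyond the scatter), which exchanged a bromo terminus for the longer acid-bearing chain and gave a modest rise in the number. Shortening that chain while keeping the acid undoes part of that lengthening; with no step that tests chain length alone, the expectation is a small move at most, if anything toward the number of compound 1, and quite possibly nothing beyond the scatter.

The estimated step from compound 2 to compound 3 in this assay is a 1.4-fold lower number from compound 2 to compound 3 (0.15 log units; within the scatter). For compound 3 the expected value is 7000 nM, with a range from 3000 nM to 16000 nM.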

Compound 3, half-maximal inhibitory concentration: 2100 nM
Compound 3: the middle estimate sits 3.3-fold (0.52 log units) above what was measured; the measured number lies below the stated range.
By their numbers in this assay, from the lowest: compounds 3 and 1 (each within the scatter of the next); then compound 2.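

In this assay, shortening the acid-bearing chain with the acid retained gives a 4.8-fold lower number from compound 2 to compound 3 (0.68 log units; beyond the scatter), so chain length at this position moves the number on its own, a point the change of end group and chain together in the earlier step could not separate. The carboxylic acid as such does not go with the high number of compound 2: compound 3 carries the same acid, and against the bromo terminus the step reads a 1.9-fold lower number from compound 1 to compound 3 (0.28 log units; within the scatter), which leaves these two compounds indistinguishable. Nothing at hand explains why the shorter acid chain gives the lower number.

As far as these compounds go, two acid-bearing chains fix no trend, so it remains open whether the number keeps falling with a still shorter chain ending in the carboxylic acid, or whether a chain of intermediate length breaks the line between compound 2 and compound 3. Also open, from the compounds shown here alone, is how an amine or a primary amide at the end of the chain would compare with the acid and the bromo terminus at a matched chain length.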